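The source may report more compounds than this note shows. Statements on the series, on what has been measured and on what is new or still open speak of the compounds shown alone.

Compound 1 `CCC(COc1cccc([N+](=O)[O-])c1)OC(=O)NCc1ccccc1` gives in an assay for inhibition of zeta-carotene desaturase, chloroplastic/chromoplastic (Capsicum annuum), using a Dixon plot, with a stated time of 8 h (on this read-out lower numbers stand for stronger inhibition and higher numbers for weaker inhibition), the value > 100000 nM, which is a limit of the assay and not a number.
Compound 2 `CCOC(=O)c1cccc(OCC(CC)OC(=O)NCc2ccccc2)c1` gives in this assay the value > 100000 nM, again a limit.
Compound 3 `CCC(COc1cccc(C(=O)O)c1)OC(=O)NCc1ccccc1` gives in this assay the value > 100000 nM, also a limit.

Compound 3 therefore stands at the limit at which every measured value sits (the limit of > 100000 nM in this assay, at which 3 of the 3 values shown sit); no number places it above or below the other two. The change to compound 4 `CCC(COc1cccc(NC(C)=O)c1)OC(=O)NCc1ccccc1` is acetamido in place of carboxy on an aromatic carbon. Three measured steps exist, a step that the two limits leave unreadable from compound 1 to compound 2, a step that the two limits leave unreadable from compound 1 to compound 3 and a step that the two limits leave unreadable from compound 2 to compound 3, and none has a readable size, so none gives a direction for this change. Compound 4 is therefore expected to show a step that the limit leaves unreadable from compound 3 to compound 4, most likely again a limit rather than a number. Compound 4 is estimated at 150000 nM, with a range from 40000 nM to 500000 nM.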

Compound 4, half-maximal inhibitory concentration: > 100000 nM
Compound 4 was reported as a limit (the forecaster's own chance of this, stated with the estimate: 80%); the middle value lies beyond the limit too.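

Compound 4 gives > 100000 nM in this assay, again a limit of the assay, so its steps from compound 1, compound 2 and compound 3 cannot be read. The compounds shown leave open whether any substituent on the shared core gives a numerical value.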